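This account rests on a few compounds, and the source may have more. Where it says the series, first, only, none or still open, it means among the compounds named here.

Measured compounds:
- compound 1, `CCCCCCc1cc2cn(Cc3cn(-c4ccccc4F)nn3)c(=O)nc2o1`, > 100000 nM
- compound 2, `O=c1nc2oc(CCCCl)cc2cn1Cc1cn(-c2ccccc2F)nn1`, 66500 nM
- compound 3, `O=c1c(I)cn(Cc2cn(Cc3ccccc3)nn2)c(=O)n1Cc1cn(Cc2ccccc2)nn1`, 15100 nM

These three compounds were tested in a functional assay on HeLa cells (Homo sapiens) for antiproliferative activity, read by MTT assay, with a stated time of 72 h; a higher number here means a weaker inhibitor, a lower number a stronger inhibitor. For compound 1 the result is a limit of the assay, not a number: > 100000 nM, which is the limit of > 100000 nM in this assay, at which 1 of the 3 values shown sits. Among the two actual numbers, compound 2 stands highest with 66500 nM, and compound 3, with 15100 nM, gives a lower number by a gap that lies beyond the scatter.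

Among the measured compounds shown here, the single step measured between neighbours is an at least 1.5-fold lower number from compound 1 to compound 2 (0.17 log units; that floor lies within the scatter), a change on the side chain of the shared core, and its floor lies within the scatter.

Compound 4, `O=c1nc2oc(CCCCl)cc2cn1Cc1cn(-c2ccc(Cl)cc2)nn1`, is not yet measured. It differs from compound 2 in one place: 4-chlorophenyl in place of 2-fluorophenyl on an aromatic nitrogen. For the measured compounds named here, no measured step touches this aryl group on the ring nitrogen, so the chain step from compound 1 to compound 2 gives no guide to its size or direction. With nothing to build on, the expectation for a 1.1-fold lower number from compound 2 to compound 4 (0.04 log units; within the scatter) is no step beyond the scatter. Compound 4 is therefore estimated at 60000 nM, within a range from 20000 nM to 180000 nM.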

Compound 4, half-maximal inhibitory concentration: 60200 nM
Beside the measured number, compound 4's estimate is 1.0-fold (0.00 log units) below it, within the range that was stated.
By their numbers in this assay, from the lowest: compound 3; then compounds 4 and 2 (each within the scatter of the next). At a limit, above all of these: compound 1.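

In this assay, 4-chlorophenyl in place of 2-fluorophenyl on the aromatic nitrogen of the five-membered ring gives a 1.1-fold lower number from compound 2 to compound 4 (0.04 log units; within the scatter) and so separates compound 2 from compound 4 by no more than repeated measurements of one compound might. Among the compounds shown here, this is the first reading at this position, which the earlier step on the side chain could not provide, and it shows that these two halogen-bearing phenyl groups cannot be told apart in this test. Both the halogen and its place on the phenyl ring differ in this one exchange, so neither can be judged alone, and nothing measured here gives a reason for the result.

From the compounds shown here alone, it remains open whether a phenyl group carrying an amine or a carboxylic acid on this nitrogen would move the number beyond the scatter, or whether a plain phenyl group would match these two. Also open, going by these compounds, is whether 4-chlorophenyl would behave the same way alongside the longer chain of compound 1, which shares the core of compound 2 and compound 4.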